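The source may report more compounds than this note shows. Statements on the series, on what has been measured and on what is new or still open speak of the compounds shown alone.

Notes on the series built around the shared core of compound 1 `COCCOc1cc(C)c(-c2cccc(CNc3ccc(OCC(=O)O)c(F)c3)c2)c(C)c1`. In a functional assay on CHO cells for agonist activity at Free fatty acid receptor 1 (Homo sapiens), read by FLIPR and calcium flux (on this read-out higher numbers stand for an effect only at larger amounts of compound and lower numbers for an effect already at smaller amounts), compound 1 gives 51.6 nM. Compound 2 `Cc1ccccc1-c1cccc(CNc2ccc(OCC(=O)O)c(F)c2)c1`, which lacks the alkoxy chain of the other two, gives 4.8 nM in this assay. Compound 3 `CCCOc1ccc(-c2cccc(CNc3ccc(OCC(=O)O)c(F)c3)c2)c(C)c1` gives 41.3 nM and so stands second highest of the three numbers; its value and that of compound 1 lie within the scatter of each other, while the step of an 8.6-fold higher number from compound 2 to compound 3 (0.93 log units; beyond the scatter) lies beyond it. Compound 4 `COCCOc1ccc(-c2cccc(CNc3ccc(OCC(=O)O)c(F)c3)c2)c(C)c1` differs from compound 3 in one place: methoxy in place of methyl on a saturated chain carbon, two bonds along the chain from an oxygen on an aromatic ring. Among the measured compounds shown here, no measured step isolates this exchange. For the measured compounds named here, the only single-point step in the set, an 8.6-fold higher number from compound 2 to compound 3 (0.93 log units; beyond the scatter), concerns propoxy in place of hydrogen and does not address methoxy for methyl within the chain. Compound 1 carries the same 2-methoxyethoxy chain as compound 4 but also a second methyl, so compound 1 against compound 3 is not a clean comparison; still, their two values sit within the scatter. On this basis no step beyond the scatter is expected, a 1.1-fold higher number from compound 3 to compound 4 (0.04 log units; within the scatter). Compound 4 is therefore estimated at 45 nM, with a range from 20 nM to 100 nM in this assay.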

Compound 4, half-maximal effective concentration: 41.9 nM
For compound 4 the middle estimate is 1.1-fold (0.03 log units) above the measured one; the measured number falls inside the stated range.
By their numbers in this assay, from the lowest: compound 2; then compounds 3, 4 and 1 (each within the scatter of the next).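

Propoxy to 2-methoxyethoxy now has a direct reading: in this assay, the exchange of methyl for methoxy on this saturated chain carbon gives a 1.0-fold higher number from compound 3 to compound 4 (0.01 log units; within the scatter), so this change leaves the number within the scatter. The alkoxy step from the unsubstituted aromatic carbon also holds for a second chain: 2-methoxyethoxy in place of hydrogen gives an 8.7-fold higher number from compound 2 to compound 4 (0.94 log units; beyond the scatter), close in size to the propoxy step, an 8.6-fold higher number from compound 2 to compound 3 (0.93 log units; beyond the scatter). Among the compounds shown here, the comparison with compound 1 isolates the second methyl for the first time, and hydrogen in place of methyl on an aromatic carbon gives a 1.2-fold lower number from compound 1 to compound 4 (0.09 log units; within the scatter), again within the scatter. No measurement is available that could explain why these exchanges leave the number within the scatter.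

Open, from the compounds shown here alone, is whether a hydroxyl, an amine or a carboxylic acid in place of the methoxy would stay within the scatter of compound 4, and whether a longer chain such as 3-methoxypropoxy would do the same. Also open, going by these compounds, is whether hydrogen in place of methyl would read the same with propoxy or without any alkoxy chain.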